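Shortening the side chain of compound 1

The source may hold more compounds than are shown below. What is called first, only, known or untested is meant among the compounds shown, and "the series" means these compounds.

For the measured compounds named here, in a functional assay on A549 cells (Homo sapiens) for cytotoxicity, read by MTT assay (a higher number here means a weaker inhibitor, a lower number a stronger inhibitor), compound 1 (`COc1ccc(-c2oc3c(CC=C(C)C)c(OC/C=C/C(=O)O)cc(O)c3c(=O)c2O)cc1`) gives 22900 nM as the only true number so far. Compound 2 (`COc1ccc(-c2oc3c(CC=C(C)C)c(OC/C=C/C(=O)O)cc(O)c3c(=O)c2OC/C=C/C(=O)O)cc1`) reads > 100000 nM as a limit of the assay and not as a number.

Compound 3 (`COc1ccc(-c2oc3c(CC=C(C)C)c(OCC(=O)O)cc(O)c3c(=O)c2O)cc1`) has not been measured yet. It keeps the core of compound 1 and alters one chain. The difference is carboxy in place of 2-carboxyethenyl on a saturated chain carbon bound to an oxygen on an aromatic ring and in words carboxy stands in place of 2-carboxyethenyl on a saturated chain carbon bound to an oxygen on an aromatic ring.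

Going by the values given here, only one measured step comes close. That step is an at least 4.3-fold higher number from compound 1 to compound 2 (0.64 log units; beyond the scatter) and it puts 3-carboxyprop-2-en-1-yl in place of hydrogen on an oxygen on an aromatic ring. It adds a chain, whereas compound 3 only shortens one, so it is a poor guide here. The best anchor is therefore compound 1 at 22900 nM and no shift beyond the scatter is expected. The estimated change is a 1.1-fold higher number from compound 1 to compound 3 (0.04 log units; within the scatter) and it could go either way. For compound 3 the expected value is 25000 nM with 10000 nM and 65000 nM as the estimated ends of its range.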

Compound 3, half-maximal inhibitory concentration: 16700 nM
For compound 3 the middle estimate is 1.5-fold (0.18 log units) above the measured one; low and high end bracket the measured number.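

Putting carboxy in place of 2-carboxyethenyl on a saturated chain carbon bound to an oxygen on an aromatic ring gives a 1.4-fold lower number from compound 1 to compound 3 (0.14 log units; within the scatter) in this assay. At this position, then, the chain can go from 3-carboxyprop-2-en-1-yl to the shorter carboxymethyl, and lose its chain double bond, without a change beyond the scatter, whereas adding a second chain gave an at least 4.3-fold higher number from compound 1 to compound 2 (0.64 log units; beyond the scatter). The reading of compound 2, > 100000 nM, is a limit of the assay and not a number, and it is the only limit among the compounds shown: the limit of > 100000 nM in this assay, at which 1 of the 3 values shown sits.

From the compounds shown here alone, both compound 1 and compound 3 end this chain in a carboxylic acid, so it remains open whether the same reading would hold with a methyl ester or an amine at the chain end. Going by these compounds, it also remains open whether a longer saturated chain, such as 3-carboxypropyl, would read like these two, since only the carboxymethyl and 3-carboxyprop-2-en-1-yl chains can be compared here.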